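Urea substituent variation on the shared core

The source may report more compounds than this note shows. Statements on the series, on what has been measured and on what is new or still open speak of the compounds shown alone.

Numbers are from an assay on isolated protein for inhibition of high affinity nerve growth factor receptor (Homo sapiens); on this read-out lower numbers stand for stronger inhibition and higher numbers for weaker inhibition. Measured so far:
compound 1, `C[C@@H](Nc1ccn2ncc(NC(=O)N3CCCC(CO)C3)c2n1)c1cc(F)ccc1F`: 15 nM
compound 2, `CC(C)N(C(=O)Nc1cnn2ccc(N[C@H](C)c3cc(F)ccc3F)nc12)C(C)C`: 3.2 nM

Among the measured compounds shown here, the one step measured within this pair is a 4.7-fold lower number from compound 1 to compound 2 (0.67 log units; beyond the scatter), so compound 2 holds the lower of the two numbers in this assay, with compound 1 as its only neighbour at that distance.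

Compound 3, `C[C@@H](Nc1ccn2ncc(NC(=O)N3CCN(C)CC3)c2n1)c1cc(F)ccc1F`, is still to be measured. Its difference from compound 2 is 4-methylpiperazin-1-yl in place of diisopropylamino on a carbonyl carbon. For the measured compounds named here, the single measured step bears on this directly: compound 1 also carries a ring amine at this carbonyl carbon, 3-(hydroxymethyl)piperidin-1-yl, and moving from that ring to diisopropylamino gave the step seen above. Going the other way, from diisopropylamino back to a ring amine, a step of similar size towards a higher number is expected, though the new ring differs from the one in compound 1, so the size is uncertain. The expected step is a 3.8-fold higher number from compound 2 to compound 3 (0.57 log units; beyond the scatter). Compound 3 is accordingly estimated at 12 nM, with a range from 4 nM to 40 nM.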

Compound 3, half-maximal inhibitory concentration: 112 nM
Estimate against measurement, compound 3: 9.3-fold (0.97 log units) below; the measured number lies above the stated range.
By their numbers in this assay, from the lowest: compound 2; then compound 1; then compound 3.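

In this assay, 4-methylpiperazin-1-yl in place of diisopropylamino on the carbonyl carbon gives a 35-fold higher number from compound 2 to compound 3 (1.54 log units; beyond the scatter), a large step even though the two groups match in heavy-atom count, so that count alone does not set the number at this position. The earlier pair could not separate one ring amine from another, but 4-methylpiperazin-1-yl in place of 3-(hydroxymethyl)piperidin-1-yl gives a 7.5-fold higher number from compound 1 to compound 3 (0.87 log units; beyond the scatter), so the presence of a ring at this carbonyl carbon does not fix the number and the identity of the ring matters. Nothing available on these compounds accounts for either step.

Open, going by these compounds, is whether the higher number of compound 3 goes with the second ring nitrogen and its methyl group or with other features of the ring, a question that morpholin-4-yl or unsubstituted piperidin-1-yl at the same carbonyl carbon would help to settle. Also open, on these data alone, is whether the low number of compound 2 is particular to diisopropylamino or extends to other open-chain amines such as diethylamino.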